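Aryl-to-phenethyl exchange on the bicyclic core of compound 2

This account rests on a few compounds, and the source may have more. Where it says the series, first, only, none or still open, it means among the compounds named here.

Two compounds carry measurements in a functional assay on FM3A cells (Mus musculus) for inhibition, read by cell counting, with a stated time of 2 days; on this read-out higher numbers stand for weaker inhibition and lower numbers for stronger inhibition. Compound 1 `COc1ccc(-c2nn3cc(-c4cccc(N)c4)nc3s2)cc1OC` gives 13000 nM in this assay. Compound 2 `C=C(Br)C(=O)Nc1cccc(-c2cn3nc(-c4ccc(OCC)cc4)sc3n2)c1` gives 1100 nM in this assay. On these two numbers compound 2 stands lowest; the gap to compound 1 lies beyond the usual scatter, so compound 2 is the stronger inhibitor of the pair. Within the data shown here, compound 1 and compound 2 differ in more than one place, and no single-point step between measured compounds is available.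

Compound 3 `C=C(Br)C(=O)Nc1cccc(-c2cn3nc(CCc4ccccc4)sc3n2)c1` has not yet been measured in this assay. Compared with compound 2 it carries phenethyl in place of 4-ethoxyphenyl on an aromatic carbon. The direct aromatic substituent at that carbon is thereby exchanged for a two-carbon chain ending in a phenyl, and the acceptor on the leaving group is lost. Nothing in the measured pair speaks directly to this exchange.

A moderate weakening is expected, with the step from compound 2 to compound 3 estimated at a 2.3-fold higher number from compound 2 to compound 3 (0.36 log units; beyond the scatter). Compound 3 is therefore estimated to give 2500 nM in this assay, within a range from 800 nM to 8000 nM.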

Compound 3, half-maximal inhibitory concentration: 2600 nM
Estimate against measurement, compound 3: 1.0-fold (0.02 log units) below, and the stated range covers the measured number.
By their numbers in this assay, from the lowest: compound 2; then compound 3; then compound 1.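

Among these compounds, the exchange gives the first single-point reading: in this assay, phenethyl in place of 4-ethoxyphenyl gives a 2.4-fold higher number from compound 2 to compound 3 (0.37 log units; beyond the scatter), a modest step that lies beyond the scatter. Among the compounds shown here, a directly attached aryl group is therefore not required for inhibition at this aromatic carbon, next to the ring nitrogen and next to the ring sulfur, as a phenyl ring carried on a two-carbon chain, without the ether oxygen of the leaving group, costs only this modest step. The step covers the chain and the loss of that oxygen together and does not divide between them, and no measurement at hand explains it.

Open at this carbon are benzyl and phenylpropyl, which would show how the read-out follows chain length, and a phenethyl carrying an ethoxy group on its phenyl ring, which would separate the chain from the oxygen. Also open, going by these compounds, is whether an amine or a carboxylic acid on that terminal phenyl ring moves the number in either direction.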